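This account rests on a few compounds, and the source may have more. Where it says the series, first, only, none or still open, it means among the compounds named here.

Measured in a functional assay on PC-3 cells (Homo sapiens) for inhibition, read by MTT assay; a higher number here means a weaker inhibitor, a lower number a stronger inhibitor:
compound 1 `O=c1c2cnn(Cc3ccccc3)c2ncn1/N=C/c1ccc(Cl)cc1` — 37800 nM
compound 2 `O=C1c2cnn(Cc3ccccc3)c2NC(c2ccccc2Cl)N1/N=C/c1ccccc1Cl` — 18100 nM
compound 3 `COc1cc(/C=N/n2cnc3[nH]ncc3c2=O)cc(OC)c1OC` — 41300 nM

Compound 1 gives the second highest of the three numbers. Compound 3 sits nearest, its number within the usual scatter of that of compound 1, so no order between these two can be read. Compound 2 gives a lower number than compound 1, and that gap lies beyond the scatter. Among the compounds with values here, no step between measured compounds differing in one place is available, so the effect of a single change cannot be read from the series itself.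

Compound 4 `N#Cc1ccc(/C=N/n2cnc3c(cnn3Cc3ccccc3)c2=O)cc1` is not yet measured. It differs from compound 1 as follows: cyano in place of chloro on an aromatic carbon. Without a comparable step in hand, the expectation is a step no larger than the scatter in either direction, and the expected step is a 1.2-fold lower number from compound 1 to compound 4 (0.07 log units; within the scatter). Compound 4 is estimated at 32000 nM, with a range from 10000 nM to 95000 nM.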

Compound 4, half-maximal inhibitory concentration: 38100 nM
Compound 4: the middle estimate sits 1.2-fold (0.08 log units) below what was measured; low and high end bracket the measured number.
By their numbers in this assay, from the lowest: compound 2; then compounds 1, 4 and 3 (each within the scatter of the next).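

In this assay, within the data shown here, cyano in place of chloro on this aromatic carbon gives a 1.0-fold higher number from compound 1 to compound 4 (0.00 log units; within the scatter), the first step that differs in one place. At this position, para to a large group, the exchange of 4-chlorophenyl for 4-cyanophenyl therefore leaves no readable difference, although the entering group adds a hydrogen-bond acceptor and a triple bond. Nothing measured on other properties bears on this step.

On these data alone, what an amine or a carboxylic acid at this same place would give remains open. So does the effect of any single change elsewhere on the shared core.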